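A few compounds are considered here, and "the series" means these few. Any claim that something is new, unique, unknown or untested is made for them only; others in the source may bear on it.

Compound 2, with the structure `O=C(NCc1ccc(S(=O)(=O)N2CCCCC2)cc1)c1ccn2ccnc2c1`, is one of two compounds whose numbers are in hand from an assay for inhibition of Nicotinamide phosphoribosyltransferase (Homo sapiens), read by mass spectrometry, with stated times of 15 min and 30 min; a lower number here means a stronger inhibitor, a higher number a weaker inhibitor. In this assay compound 2 gives 1800 nM, the higher of the two numbers. Its neighbour compound 1, with the structure `O=C(NCc1ccc(S(=O)(=O)N2CCCCC2)cc1)c1cc2ccncc2[nH]1`, gives 1000 nM in this assay; the step of a 1.8-fold higher number from compound 1 to compound 2 (0.26 log units; within the scatter) is the only one measured so far, and it stays within the scatter.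

Compound 3, with the structure `O=C(NCc1ccc(S(=O)(=O)N2CCCCC2)cc1)c1ccc2nc[nH]c2c1`, is not yet measured. It differs from compound 2 in one place: a group of 9 heavy atoms (7 carbon, 2 nitrogen; one five-membered aromatic ring with 2 hetero atoms, one six-membered aromatic ring of carbon only) in place of a group of 9 heavy atoms (7 carbon, 2 nitrogen; one five-membered aromatic ring with 2 hetero atoms, one six-membered aromatic ring with 1 hetero atom), on a carbonyl carbon. The two compounds share every atom and differ only in how the atoms are joined.

Among the compounds with values here, the single measured step, from compound 1 to compound 2, also swapped one bicyclic aromatic group for another of the same size on the same carbonyl carbon, and it changed the number by less than the scatter. Within the data shown here, that is the only evidence bearing on the present change, and it gives no ground to expect a step beyond the scatter in either direction in this assay.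

For compound 3, a value of 1300 nM is therefore expected in this assay, with a likely range from 450 nM to 3800 nM. This estimate amounts to an expected step of a 1.4-fold lower number from compound 2 to compound 3 (0.14 log units; within the scatter), which would stay within the scatter.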

Compound 3, half-maximal inhibitory concentration: 310 nM
The estimate for compound 3 lay 4.2-fold (0.62 log units) above the measured number, and the stated range ends above it.
By their numbers in this assay, from the lowest: compound 3; then compounds 1 and 2 (each within the scatter of the next).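

Until now, the only measured swap of one bicyclic aromatic group for another at this place, on a carbonyl carbon whose other neighbour is an amide-type nitrogen, had stayed within the scatter, so the choice of group had not been shown to matter. In this assay, the entering 1H-benzimidazol-6-yl group gives a 5.8-fold lower number from compound 2 to compound 3 (0.76 log units; beyond the scatter) with the same atoms joined differently, which shows that the arrangement of the ring atoms alone can move the number beyond the scatter at this place. The same group also gives a 3.2-fold lower number from compound 1 to compound 3 (0.51 log units; beyond the scatter) and so places compound 3 as the strongest inhibitor of the three, though nothing measured here says what lies behind either step.

The swap from compound 2 to compound 3 changes the six-membered ring to carbon only and also changes the counts of hydrogen-bond donors and acceptors, and these compounds cannot separate those changes. As far as these compounds go, it also remains open whether a 1H-benzimidazol-6-yl group carrying a methyl group, a fluorine or an amine would keep, lower or raise the number in this assay.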